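This account rests on a few compounds, and the source may have more. Where it says the series, first, only, none or still open, it means among the compounds named here.

Measured in a functional assay on CHO cells for antagonist activity at Orexin receptor type 2 (Homo sapiens), read by FLIPR and calcium flux; on this read-out lower numbers stand for stronger inhibition and higher numbers for weaker inhibition:
compound 1 `Cc1ccc(NC(=O)CSc2nnc(-c3ccoc3C)n2Cc2ccco2)cc1`: 39.8 nM
compound 2 `Cc1cccc(NC(=O)CSc2nnc(-c3ccoc3C)n2Cc2ccco2)c1`: 50.1 nM

Compound 1 has the lowest of the two numbers shown, yet the step of a 1.3-fold higher number from compound 1 to compound 2 (0.10 log units; within the scatter) is within the scatter, so the two compounds are not separated. Compound 3 `CC(=O)c1ccc(NC(=O)CSc2nnc(-c3ccoc3C)n2Cc2ccco2)cc1` differs from compound 1 by acetyl in place of methyl on an aromatic carbon. Within the data shown here, the only measured step, a 1.3-fold higher number from compound 1 to compound 2 (0.10 log units; within the scatter), concerns a moved methyl and does not bear on an acetyl entering; no measured comparison covers this change. Without guidance, the expectation for compound 3 is a step of a 1.5-fold higher number from compound 1 to compound 3 (0.18 log units; within the scatter) of no clear direction, wide in range. Compound 3 is estimated at 60 nM, between 20 nM and 200 nM.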

Compound 3, inhibition constant: 31.6 nM
Beside the measured number, compound 3's estimate is 1.9-fold (0.28 log units) above it, within the range that was stated.
By their numbers in this assay, from the lowest: compounds 3, 1 and 2 (each within the scatter of the next).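

In this assay, acetyl in place of methyl on an aromatic carbon, para to a large group, leaves the compounds unseparated: a 1.3-fold lower number from compound 1 to compound 3 (0.10 log units; within the scatter). The step on the amide-type nitrogen, 4-acetylphenyl in place of 3-methylphenyl, also does not separate them: a 1.6-fold lower number from compound 2 to compound 3 (0.20 log units; within the scatter). This position therefore accepts a larger group carrying a hydrogen-bond acceptor without a step beyond the scatter, and nothing available explains these numbers.

From the compounds shown here alone, whether an amine, a carboxylic acid or a longer chain at this position would separate from compound 1 remains open.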